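Moving the Hydroxyl Within the Hydrazone Tail

The compounds below may be only part of what the source reports. "The series", "measured", "known", "first", "only" and "open" are said of these compounds alone.

Compound 1, `Brc1ccccc1CSc1nnc(-c2ccncc2)n1-c1ccccc1`: 20200 nM
Compound 2, `Clc1cccc(CSc2nnc(-c3ccncc3)n2-c2ccccc2)c1`: 9820 nM
Compound 3, `O=C(CSc1nnc(-c2ccncc2)n1-c1ccccc1)N/N=C/c1ccc(O)cc1`: > 50000 nM

In a functional assay on HCT-116 cells (Homo sapiens) for inhibition, read by MTT assay, with a stated time of 48 h (on this read-out higher numbers stand for weaker inhibition and lower numbers for stronger inhibition), compound 1 gives 20200 nM and compound 2 gives 9820 nM; the change recorded is a 2.1-fold lower number from compound 1 to compound 2 (0.31 log units; beyond the scatter). Compound 3 gives > 50000 nM, which is a limit of this assay and not a number. Compound 3 thus stands apart from the other two, at the limit of > 50000 nM in this assay, at which 1 of the 3 values shown sits. Compound 4, `O=C(CSc1nnc(-c2ccncc2)n1-c1ccccc1)N/N=C/c1ccccc1O`, differs from compound 3 by 2-hydroxyphenyl in place of 4-hydroxyphenyl on a carbon with a double bond to nitrogen. For the measured compounds named here, no measured step moves a hydroxyl within a hydroxyphenyl ring; the only measured step, a 2.1-fold lower number from compound 1 to compound 2 (0.31 log units; beyond the scatter), concerns a different aryl group on the other side of the core and was modest. Compound 4 is therefore expected to remain near the limit, with no step beyond the scatter, a step that the limit leaves unreadable from compound 3 to compound 4. For compound 4 the estimated value in this assay is 60000 nM, ranging from 20000 nM to 200000 nM.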

Compound 4, half-maximal inhibitory concentration: 7060 nM
Compound 4: the middle estimate sits 8.5-fold (0.93 log units) above what was measured, outside the stated range (below it).
By their numbers in this assay, from the lowest: compounds 4 and 2 (each within the scatter of the next); then compound 1. At a limit, above all of these: compound 3.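

The hydrazone tail is sensitive to where its hydroxyl sits: in this assay, 2-hydroxyphenyl in place of 4-hydroxyphenyl on a carbon with a double bond to nitrogen, with the same atoms joined differently, brings an at least 7.0-fold lower number from compound 3 to compound 4 (0.85 log units; beyond the scatter). The earlier step concerned only the aryl group on the other side of the core, so this is the only step shown within the tail. For compound 3 the figure is a limit of the assay and not a number: the limit of > 50000 nM in this assay, at which 1 of the 4 values shown sits.

Going by these compounds, whether the hydroxyl itself is needed remains open. The compounds shown do not tell what a methoxy group or an amine in its place would give.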